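This account rests on a few compounds, and the source may have more. Where it says the series, first, only, none or still open, it means among the compounds named here.

Working notes on the series. Compound 2 `O=C([C@@H]1CCCN(S(=O)(=O)c2ccc(S(=O)(=O)C3COC3)cc2)C1)N1CCC(F)(F)CC1` gives, in a functional assay on MIA PaCa-2 cells (Homo sapiens) for inhibition, read by MTT assay, with a stated time of 7 days (a lower number here means a stronger inhibitor, a higher number a weaker inhibitor), 110 nM. Of the three numbers in hand it sits together with compound 1 `O=C([C@@H]1CCCN(S(=O)(=O)c2ccc(S(=O)(=O)N3CC[C@@H](O)C3)cc2)C1)N1CCC(F)(F)CC1`, which in this assay gives 210 nM; the step of a 1.9-fold lower number from compound 1 to compound 2 (0.28 log units; within the scatter) is within the scatter. Compound 3 `CCN(CC)S(=O)(=O)c1ccc(S(=O)(=O)N2CCC[C@@H](C(=O)N[C@H]3CCOC3)C2)cc1` stands well apart from both, giving 1670 nM in this assay, but it differs from compound 2 at more than one place, so its number says little on its own about any single change.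

Compound 4 `CN(C)S(=O)(=O)c1ccc(S(=O)(=O)N2CCC[C@@H](C(=O)N3CCC(F)(F)CC3)C2)cc1` is the next member: dimethylamino in place of oxetan-3-yl on a sulfonyl sulfur. For the measured compounds named here, the only measured step that touches the same sulfonyl sulfur is the one from compound 1 to compound 2, an exchange of 3-hydroxypyrrolidin-1-yl for oxetan-3-yl, and it stayed within the scatter. On that basis no step beyond the scatter is expected in this assay for compound 4; the estimated step is a 1.8-fold higher number from compound 2 to compound 4 (0.26 log units; within the scatter). For compound 4 the expected number in this assay is 200 nM, with a range from 70 nM to 600 nM.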

Compound 4, half-maximal inhibitory concentration: 118 nM
Estimate against measurement, compound 4: 1.7-fold (0.23 log units) above, within the range that was stated.
By their numbers in this assay, from the lowest: compounds 2, 4 and 1 (each within the scatter of the next); then compound 3.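

In this assay, the exchange of oxetan-3-yl for dimethylamino on the sulfonyl sulfur leaves the number unresolved from that of the oxetane (a 1.1-fold higher number from compound 2 to compound 4 (0.03 log units; within the scatter)), so a group with no ring can take this place without a step beyond the scatter. The exchange of 3-hydroxypyrrolidin-1-yl for dimethylamino is also unresolved (a 1.8-fold lower number from compound 1 to compound 4 (0.25 log units; within the scatter)), which places all three groups on this sulfonyl sulfur within the scatter of one another on the shared core of compounds 1, 2 and 4, and no group among them goes against this. No measurement in hand bears on why these groups read alike.

The compounds shown leave open whether this flat reading holds for a group carrying a basic amine, such as piperazin-1-yl, or a carboxylic acid at the same place. They also leave open whether a longer chain on the sulfonyl sulfur would produce the first step there beyond the scatter.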